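Aryl replacement on the dienone end of compound 1

The compounds below may be only part of what the source reports. "The series", "measured", "known", "first", "only" and "open" are said of these compounds alone.

Measured compounds in a functional assay on THP-1 cells (Homo sapiens) for inhibition, read by sulforhodamine B assay, with a stated time of 48 h, tested at 50 uM; on this read-out lower numbers stand for less inhibition of growth and higher numbers for more inhibition of growth at the one concentration tested:
compound 1 `COc1cc(/C=C/C(=O)/C=C/c2cccc3ccccc23)ccc1OCc1cn(CCCCOc2cc(=O)oc3ccccc23)nn1`: 54%
compound 2 `COc1ccc(/C=C/C(=O)/C=C/c2ccc(OCc3cn(CCOc4cc(=O)oc5ccccc45)nn3)c(OC)c2)cc1`: 78%
compound 3 `COc1cc(/C=C/C(=O)/C=C/c2cccc3ccccc23)ccc1OCc1cn(CCOc2cc(=O)oc3ccccc23)nn1`: 89%

Compound 1 stands lowest of the three numbers in this assay. Its nearest neighbour on the numbers is compound 2, whose value sits higher by a gap beyond the scatter, and compound 3 lies further up still, again beyond the scatter. For the measured compounds named here, compound 1 and compound 3 share the same aryl group at the dienone end and differ only in the chain that carries the coumarin; no step is recorded for that pair, so the two values are simply noted.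

Compound 4 `COc1ccc(/C=C/C(=O)/C=C/c2ccc(OCc3cn(CCCCOc4cc(=O)oc5ccccc45)nn3)c(OC)c2)cc1OC` is not yet measured. It differs from compound 1 in one place: 3,4-dimethoxyphenyl in place of naphthalen-1-yl on a double-bonded chain carbon bound to a double-bonded chain carbon

Going by the values given here, the one recorded step that touches this position is a number 11 percentage points higher from compound 2 to compound 3 (beyond the scatter). Read in the opposite direction, it suggests that exchanging the naphthalen-1-yl for a methoxy-bearing phenyl costs a modest amount of growth inhibition, though that step was run on the shorter chain and with 4-methoxyphenyl rather than 3,4-dimethoxyphenyl, so it carries over only loosely.

On that basis a modest downward step is expected, a number 9 percentage points lower from compound 1 to compound 4 (within the scatter), and compound 4 is estimated at 45% in this assay, within the range 25% to 65%.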

Compound 4, percent growth inhibition at one concentration: 59%
Compound 4: the middle estimate sits 14 percentage points below what was measured; measured number inside the range.
By their numbers in this assay, from the lowest: compounds 1 and 4 (each within the scatter of the next); then compound 2; then compound 3.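

In this assay, replacing naphthalen-1-yl with 3,4-dimethoxyphenyl on a double-bonded chain carbon bound to a double-bonded chain carbon gives a number 5 percentage points higher from compound 1 to compound 4 (within the scatter) and so leaves the read-out unresolved from compound 1, even though the entering group has one six-membered aromatic ring of carbon only and 2 hydrogen-bond acceptors. The earlier step at this position, a number 11 percentage points higher from compound 2 to compound 3 (beyond the scatter), was beyond the scatter, but it involved 4-methoxyphenyl and the shorter chain, whereas no such separation between the aryl groups appears on the chain of compound 1; with both the aryl group and the chain differing, these two steps cannot show which of them accounts for the contrast. No available evidence bears on the reason for this behaviour at the position.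

From the compounds shown here alone, the reading of 3,4-dimethoxyphenyl on the shorter chain of compound 3 remains open, and it would separate the contribution of the aryl group from that of the chain. Also open, going by these compounds, is how a phenyl group carrying a dimethylamino group or a carboxylic acid would read at this position, and whether the similarity of these two compounds at a single test concentration would persist across a range of concentrations.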